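Series notes: aryl swap from compound 3 to compound 4

This account rests on a few compounds, and the source may have more. Where it says the series, first, only, none or still open, it means among the compounds named here.

Measured in an assay on isolated protein with Bile acid receptor (Homo sapiens) as the target; a lower number here means that less compound is needed, a higher number that more compound is needed for the effect:
- compound 1 `COC(=O)/C=C/c1cccc(N(Cc2ccc(/C=C/c3ccccc3F)cc2)C(=O)C2CCCCC2)c1`: 64 nM
- compound 2 `COC(=O)/C=C/c1cccc(N(Cc2ccc(-c3ccc(F)c(F)c3)cc2)C(=O)C2CCCCC2)c1`: 72 nM
- compound 3 `COC(=O)/C=C/c1cccc(N(Cc2ccc(-c3cccc(Cl)c3)cc2)C(=O)C2CCCCC2)c1`: 94 nM

Compound 3 holds the highest of the three numbers in this assay; compound 2 is nearest and compound 1 furthest, and both gaps are within the scatter, so no order among the three can be claimed. Compound 4 `COC(=O)/C=C/c1cccc(N(Cc2ccc(-c3ccc(C(C)(C)C)cc3)cc2)C(=O)C2CCCCC2)c1` differs from compound 3 in one place: 4-(tert-butyl)phenyl in place of 3-chlorophenyl on an aromatic carbon. Among the compounds with values here, two measured steps touch the same position. The step of a 1.3-fold higher number from compound 2 to compound 3 (0.12 log units; within the scatter) exchanges one substituted phenyl for another there, and the step of a 1.5-fold higher number from compound 1 to compound 3 (0.17 log units; within the scatter) replaces a longer group at the same aromatic carbon; neither moves the number beyond the scatter. The change to compound 4 again keeps a single six-membered aromatic ring of carbon only at this position, now carrying the substituent para to a large group, with the composition as counted in the change. A tert-butyl substituent has not been sampled in this series, so the uncertainty is wider than the measured steps alone suggest. On the measured steps, the step of a 1.1-fold higher number from compound 3 to compound 4 (0.03 log units; within the scatter) is expected to fall within the scatter. Compound 4 is therefore estimated at 100 nM in this assay, with a range from 40 nM to 300 nM.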

Compound 4, half-maximal effective concentration: 132 nM
Beside the measured number, compound 4's estimate is 1.3-fold (0.12 log units) below it, and the stated range covers the measured number.
By their numbers in this assay, from the lowest: compounds 1, 2, 3 and 4 (each within the scatter of the next, the first and the last beyond it).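

In this assay, the aromatic carbon still takes 4-(tert-butyl)phenyl, with 10 heavy atoms in place of the 7 of 3-chlorophenyl: the step of a 1.4-fold higher number from compound 3 to compound 4 (0.15 log units; within the scatter) stays inside the usual variation, and so does the step of a 1.8-fold higher number from compound 2 to compound 4 (0.26 log units; within the scatter) for the exchange of 3,4-difluorophenyl. The new feature is the step of a 2.1-fold higher number from compound 1 to compound 4 (0.31 log units; beyond the scatter) that, unlike every earlier step at this position, is printed as beyond the scatter, so the groups sampled here are no longer all indistinguishable, although the gap is small and separates only the two ends of the series. No supporting data bear on what lies behind this gap at this position.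

The step between compound 1 and compound 4 changes the 2-(2-fluorophenyl)ethenyl group as a whole, so it cannot be assigned to the ethenyl link, the fluorine or the tert-butyl group alone. From the compounds shown here alone, whether an amine or a carboxylic acid on this phenyl ring, or a longer chain in place of the tert-butyl group, would move the number further remains open.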